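Phenethyl Ether to Dichlorobenzyl Ether on a Shared Core

A few compounds are considered here, and "the series" means these few. Any claim that something is new, unique, unknown or untested is made for them only; others in the source may bear on it.

Compound 1 `Cc1nn(-c2ncnc3nc[nH]c23)c2c1C(OCCc1ccccc1)CC(=O)N2` is the most potent of the three compounds measured in a functional assay on HEK293 cells for agonist activity at G-protein coupled receptor 39 (Homo sapiens), read by scintillation proximity assay and inositol phosphate accumulation, with a stated time of 75 min, in the presence of a further agent that is not named here (on this read-out higher numbers stand for an effect only at larger amounts of compound and lower numbers for an effect already at smaller amounts), where compound 1 gives 3 nM. Compound 2 `O=C1/C(=C/NCCCO)C(c2ccccc2)=NN1c1nc2ccccc2s1` gives 200 nM in this assay, and compound 3 `C=CCN1c2c(n(C)c(=O)n(C)c2=O)NC1N/N=C/c1ccc(O)cc1O` gives 340 nM; both of these stand beyond the scatter from compound 1, which holds the lowest number of the set. Among the measured compounds shown here, compounds 2 and 3 are built on different frameworks from compound 1, and no pair of measured compounds differs in only one place, so the measured set offers no isolated step to lean on.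

Compound 4 `Cc1nn(-c2ncnc3nc[nH]c23)c2c1C(OCc1ccc(Cl)cc1Cl)CC(=O)N2` keeps the core of compound 1 and alters it in a single place: 2,4-dichlorophenyl in place of benzyl on a saturated chain carbon bound to an oxygen on a saturated carbon. The same change, cut one bond further out, reads phenethyl to 2,4-dichlorobenzyl. With no measured pair isolating a change of this kind in this assay, the expectation rests only on the kept remainder of compound 1 and the nature of the swap. The expected step, a 3.3-fold higher number from compound 1 to compound 4 (0.52 log units; beyond the scatter), is a moderate move toward a higher number, somewhat beyond the scatter. Compound 4 is accordingly estimated at 10 nM in this assay, with a range from 2 nM to 60 nM.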

Compound 4, half-maximal effective concentration: 4 nM
Estimate against measurement, compound 4: 2.5-fold (0.40 log units) above; the measured number falls inside the stated range.
By their numbers in this assay, from the lowest: compounds 1 and 4 (each within the scatter of the next); then compounds 2 and 3 (each within the scatter of the next).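

In this assay, among the compounds shown here, exchanging phenethyl for 2,4-dichlorobenzyl on the shared core amounts to a 1.3-fold higher number from compound 1 to compound 4 (0.12 log units; within the scatter), the first step in this set that isolates a single place, and the two compounds stand within the scatter of each other. At this place on a saturated chain carbon bound to an oxygen on a saturated carbon, benzyl and 2,4-dichlorophenyl therefore give numbers that this read-out cannot tell apart, even though the entering group carries two chlorine atoms and the leaving group carries none. No measurement available here offers an explanation for this outcome.

This single step changes the chain and adds both chlorine atoms at once, so the compounds shown leave open what each of these alterations would do alone, as a plain benzyl or a 4-chlorobenzyl in the same place would show. They also leave open whether this place would accept an amine or a carboxylic acid on the aromatic ring, or a chain longer than phenethyl.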